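The source may hold more compounds than are shown below. What is called first, only, known or untested is meant among the compounds shown, and "the series" means these compounds.

Compound 3 `CC1=C(C(=O)CC(C)C)C(c2cccs2)NC(=O)N1` is the reference point of this step; in an assay on membranes from CHO cells for displacement of a labelled ligand from adenosine receptor A1 (Homo sapiens), read by scintillation counting, with a stated time of 60 min, tested at 1 uM (on this read-out higher numbers stand for more inhibition at the one concentration tested (going by the name of the read-out) and lower numbers for less inhibition), compound 3 gives 19%. Among the three numbers so far it stands second highest. Compound 2 `CC1=C(C(=O)CC(C)C)C(c2ccoc2)NC(=O)N1` gives 23%, and the step of a number 4 percentage points lower from compound 2 to compound 3 (within the scatter) lies within the scatter, so no order between compound 2 and compound 3 is claimed. For the measured compounds named here, compound 1 `COC(=O)C1=C(C)NC(=O)NC1c1cccs1` gives 6%; the step of a number 13 percentage points higher from compound 1 to compound 3 (beyond the scatter) is modest and beyond the scatter, and it is the only measured change on the carbonyl carbon.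

Compound 4 `CC1=C(C(=O)SC(C)C)C(c2cccs2)NC(=O)N1` differs from compound 3 in one place: isopropylsulfanyl in place of isobutyl on a carbonyl carbon. Going by the values given here, the one measured step that bears on it is a number 13 percentage points higher from compound 1 to compound 3 (beyond the scatter), isobutyl in place of methoxy on a carbonyl carbon. Among the compounds with values here, no measured step involves isopropylsulfanyl or any sulfur-bearing group at that carbon, so the bearing of that earlier step is indirect. The expectation is a small change, within the scatter, leaning downward, a number 4 percentage points lower from compound 3 to compound 4 (within the scatter). Compound 4 is estimated in this assay at 15%, with a range from 3% to 30%.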

Compound 4, a percentage reported as inhibition, at one concentration (the size of the read-out at that concentration, not a potency): 1%
Compound 4: the middle estimate sits 14 percentage points above what was measured; measured number below the stated range.
By their numbers in this assay, from the lowest: compounds 4 and 1 (each within the scatter of the next); then compounds 3 and 2 (each within the scatter of the next).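

On the carbonyl carbon, with thiophen-2-yl kept, the change can also lower the number: in this assay, isopropylsulfanyl in place of isobutyl gives a clear loss (a number 18 percentage points lower from compound 3 to compound 4 (beyond the scatter)). Isopropylsulfanyl in place of methoxy gives no separable change (a number 5 percentage points lower from compound 1 to compound 4 (within the scatter)), so among these three groups on this carbon, only isobutyl stands apart from the other two, and only by modest steps. No measurement shown accounts for this difference.

As far as these compounds go, it remains open whether an isopropoxy group, a dimethylamino group or a longer carbon chain on this carbonyl carbon would read with isobutyl or with methoxy and isopropylsulfanyl. From the compounds shown here alone, it is also open whether the loss with isopropylsulfanyl would hold with furan-3-yl on the saturated ring carbon.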